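The compounds below may be only part of what the source reports. "The series", "measured", "known", "first", "only" and "open" are said of these compounds alone.

Among the measured compounds shown here, in a functional assay on MCF7 cells (Homo sapiens) for cytotoxicity, read by MTT assay, with a stated time of 72 h (on this read-out higher numbers stand for weaker inhibition and lower numbers for stronger inhibition), compound 1 `COc1cccc(/C=C2\CCC/C(=C\c3cccc(OC)c3OC)C2=O)c1` gives 5900 nM, the higher of the two numbers so far, and compound 2 `COc1cc(/C=C2\CCC/C(=C\c3cccc(OC)c3OC)C2=O)cc(OC)c1` gives 1700 nM. Compound 3 `COc1cccc(/C=C2\CCC/C(=C\c3ccc(O)c(Cl)c3)C2=O)c1OC` carries 3-chloro-4-hydroxyphenyl in place of 3-methoxyphenyl on a double-bonded chain carbon bound to a double-bonded ring carbon. For the measured compounds named here, one measured step bears on this: methoxy in place of hydrogen on the 3-methoxyphenyl group gives a 3.5-fold lower number from compound 1 to compound 2 (0.54 log units; beyond the scatter), a modest change. Going by the values given here, no measured compound carries chlorine or hydroxy, so the evidence is thin. A similarly modest move towards a lower number is expected, as a 2.1-fold lower number from compound 1 to compound 3 (0.32 log units; beyond the scatter). For compound 3 the estimated value is 2800 nM, with an expected range of 900 nM to 8000 nM.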

Compound 3, half-maximal inhibitory concentration: 16400 nM
For compound 3 the middle estimate is 5.9-fold (0.77 log units) below the measured one; measured number above the stated range.
By their numbers in this assay, from the lowest: compound 2; then compound 1; then compound 3.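

Putting 3-chloro-4-hydroxyphenyl in place of 3-methoxyphenyl on a double-bonded chain carbon bound to a double-bonded ring carbon gives a 2.8-fold higher number from compound 1 to compound 3 (0.44 log units; beyond the scatter) in this assay. Changes to this aryl group can therefore push the number up as well as down, unlike a 3.5-fold lower number from compound 1 to compound 2 (0.54 log units; beyond the scatter). Nothing measured here accounts for the rise. Because chlorine and hydroxy enter together, the compounds shown cannot separate what each contributes. Also open, on these data alone, is how this position would respond to an amine or a carboxylic acid on the ring.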